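Methoxy on the shared core of compound 2

This account rests on a few compounds, and the source may have more. Where it says the series, first, only, none or still open, it means among the compounds named here.

Of the compounds shown here, three have been measured in an in vitro assay on P815B cells for inhibition of Indoleamine 2,3-dioxygenase 1 (Mus musculus), tested at 20 uM; on this read-out higher numbers stand for more inhibition at the one concentration tested (going by the name of the read-out) and lower numbers for less inhibition. Compound 2 `O=C(Cc1cccnc1)c1cc2ccccc2[nH]1` gives 13% in this assay and is the only compound with a number shown; compound 1 `O=C(Cc1cccnc1)c1cc2c(O)cccc2[nH]1` is reported as "not active" (no number reported) and compound 3 `O=C(Cc1cccnc1)c1cc2cc(O)ccc2[nH]1` as "not active" (no number reported), each without a figure. Compound 2 therefore stands as the one measurable entry, at a low level of inhibition, with the two hydroxy compounds below it. Compound 4 `COc1cccc2[nH]c(C(=O)Cc3cccnc3)cc12` is not yet measured. Its difference from compound 2 is methoxy in place of hydrogen on an aromatic carbon. For the measured compounds named here, no step between two measured compounds is available, so the expected size of the step in this assay rests only on the low reading of compound 2 and the two entries without a number. The estimated step of a number 4 percentage points lower from compound 2 to compound 4 (within the scatter) is small and downward, within the scatter. For compound 4 the expected result in this assay is 9%, with a range from 0% to 22%, and a fair chance that only "not active" is reported.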

Compound 4, a percentage reported as inhibition, at one concentration (the size of the read-out at that concentration, not a potency): "not active" (no number reported)
Nothing numeric was reported for compound 4; the estimate stays without a comparison.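

No new step can be read: in this assay compound 4 gives "not active" (no number reported), so its pair with compound 2 has no number to compare. The compounds shown leave open how methoxy on the shared core affects inhibition. No data shown bear on this result.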